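Swapping One Arm of a Three-Armed Phenol Core

The source may hold more compounds than are shown below. What is called first, only, known or untested is meant among the compounds shown, and "the series" means these compounds.

Three phenol arms hang from one shared core here. Compound 1 `Oc1ccc(-c2cc(-c3ccc(O)cc3)nc(-c3ccc(O)cc3)c2)cc1` carries three 4-hydroxyphenyl groups, and in a functional assay on DU-145 cells (Homo sapiens) for cytotoxicity, read by CCK-8 assay, with a stated time of 4 days (on this read-out lower numbers stand for stronger inhibition and higher numbers for weaker inhibition), compound 1 gives 3160 nM. Compound 2 `Oc1ccc(-c2cc(-c3cccc(O)c3)nc(-c3cccc(O)c3)c2)cc1` gives 1760 nM in this assay, a number that sits within the scatter of compound 1, so the two cannot be told apart. Compound 3 `Oc1ccc(-c2cc(-c3ccc(O)cc3)nc(-c3ccccc3O)c2)cc1` does not give a number in this assay but sits at the limit of the assay, > 50000 nM. Among the measured compounds shown here, the single measured step, an at least 15-fold higher number from compound 1 to compound 3 (1.19 log units; beyond the scatter), shows that replacing one 4-hydroxyphenyl arm by a 2-hydroxyphenyl arm costs a great deal of activity; how much is bounded by the limit of > 50000 nM in this assay, at which 1 of the 3 values shown sits.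

Compound 4 `Oc1ccc(-c2cc(-c3ccccc3O)cc(-c3ccc(O)cc3)n2)cc1` differs from compound 1 in the same kind of way, but on a different arm of the core: 2-hydroxyphenyl in place of 4-hydroxyphenyl on an aromatic carbon. For the measured compounds named here, the step from compound 1 to compound 3 is the only measured guide, and it was large. A loss of similar size is therefore expected for compound 4, with a fair chance that the assay again reports only a limit. For compound 4 the estimated value in this assay is 30000 nM, between 8000 nM and 100000 nM. That estimate means an expected step of a 9.5-fold higher number from compound 1 to compound 4 (0.98 log units; beyond the scatter).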

Compound 4, half-maximal inhibitory concentration: 980 nM
Estimate against measurement, compound 4: 31-fold (1.49 log units) above, and the stated range ends above it.
By their numbers in this assay, from the lowest: compounds 4, 2 and 1 (each within the scatter of the next, the first and the last beyond it). At a limit, above all of these: compound 3.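

Among the compounds shown here, the same exchange of 4-hydroxyphenyl for 2-hydroxyphenyl has no single outcome on this core: on the arm opposite the ring nitrogen, this assay shows a 3.2-fold lower number from compound 1 to compound 4 (0.51 log units; beyond the scatter), a modest gain where a loss had been the only precedent. Set beside an at least 15-fold higher number from compound 1 to compound 3 (1.19 log units; beyond the scatter), this shows that the two changes, which trade groups with the same atoms, point in opposite directions, so among these compounds the arm receiving the exchange decides whether the number falls or rises. From the compounds shown here alone, compound 3 remains a limit and not a number, so the full size of the loss on its arm stays unknown: the limit of > 50000 nM in this assay, at which 1 of the 4 values shown sits.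

Still open, going by these compounds, is whether the hydroxyl itself matters on the arm opposite the ring nitrogen, a question that a plain phenyl, a methoxyphenyl or an aminophenyl group at that place would address. Also open, on these data alone, is whether compound 4 would keep its advantage over compound 1 on cells other than those used in this assay, since a single cell type cannot show how general the gain is.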